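This account rests on a few compounds, and the source may have more. Where it says the series, first, only, none or still open, it means among the compounds named here.

Compound 2 `COc1cc(-c2nn(-c3cccc(NC(=O)Nc4ccc(Cl)c(C(F)(F)F)c4)c3)cc2-c2ccncc2)ccc1Cl` carries a urea that links the shared core to a 4-chloro-3-(trifluoromethyl)phenyl ring. In a functional assay on MDA-MB-435 cells (Homo sapiens) for inhibition, read by sulforhodamine B assay, with a stated time of 48 h (a lower number here means that less compound is tolerated, a higher number that more compound is tolerated), compound 2 gives only a limit, > 32500 nM, and no number. Compound 1 `COc1cc(-c2nn(-c3cccc(NC(=O)c4ccc(Cl)c(C(F)(F)F)c4)c3)cc2-c2ccncc2)ccc1Cl` is the matching amide, in which the same ring sits directly on the carbonyl carbon; in this assay compound 1 gives 24700 nM. Going by the values given here, the step of an at least 1.3-fold higher number from compound 1 to compound 2 (0.11 log units; that floor lies within the scatter) is the only measured change in this set, and it runs up to the limit (the limit of > 32500 nM in this assay, at which 1 of the 2 values shown sits). Compound 3 `COc1cc(-c2nn(-c3cccc(NC(=O)c4ccccc4)c3)cc2-c2ccncc2)ccc1Cl` is not yet measured. Among the compounds with values here, it differs from compound 2 by phenyl in place of (4-chloro-3-(trifluoromethyl)phenyl)amino on a carbonyl carbon: the amide type of compound 1 returns, but the chloro and trifluoromethyl substituents are gone, and no measured step tells how the plain phenyl amide behaves. The step of an at least 1.3-fold higher number from compound 1 to compound 2 (0.11 log units; that floor lies within the scatter) has a floor that sits within the scatter, so the return to an amide is expected to shift the number little, and compound 3 is expected to give around 30000 nM in this assay, with a range from 10000 nM to 80000 nM. That estimate corresponds to a step of an at least 1.0-fold lower number from compound 2 to compound 3 (0.03 log units; that floor lies within the scatter), which is expected to stay within the scatter.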

Compound 3, concentration lethal to 50% of the cells: 12300 nM
For compound 3 the middle estimate is 2.4-fold (0.39 log units) above the measured one; the range from low to high includes it.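

In this assay, going by these compounds alone, replacing the (4-chloro-3-(trifluoromethyl)phenyl)amino group on the carbonyl carbon with phenyl gives an at least 2.6-fold lower number from compound 2 to compound 3 (0.42 log units; beyond the scatter), the first step in this set that clears the usual scatter. Compounds 1 and 3 are both amides and differ only in whether the ring on the carbonyl carbon carries the chloro and trifluoromethyl groups; that comparison gives a 2.0-fold lower number from compound 1 to compound 3 (0.30 log units; within the scatter), so in this pair those two substituents produce no change that can be told from scatter. The size of the step from the urea is known only as a floor, and not as an exact figure, because compound 2 has no number, only a limit of the assay: the limit of > 32500 nM in this assay, at which 1 of the 3 values shown sits.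

The compounds shown leave open how a urea carrying a plain phenyl ring would behave, so the urea link and the two ring substituents cannot yet be weighed separately in the step away from compound 2. They also leave open whether a phenyl ring carrying only the chloro or only the trifluoromethyl group, or instead an amine or a carboxylic acid, would give a number different from that of compound 3.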